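The source may hold more compounds than are shown below. What is called first, only, known or untested is meant among the compounds shown, and "the series" means these compounds.

Working notes on the series. In a physicochemical assay for solubility, measured as kinetic solubility, at pH 2 (on this read-out lower numbers stand for lower solubility and higher numbers for higher solubility), compound 1 `CC(C)C(/C=C1\NC(=O)NC1=O)c1ccc(-c2ccc3cccc(F)c3c2)[nH]c1=O` gives 7500 nM. Compound 2 `CC(C)[C@@H](c1ccc(-c2ccc3cccc(F)c3c2)[nH]c1=O)[C@@H]1OC(=O)NC1=O` gives 6900 nM, and compound 3 `CC(C)/C(=C1\C(=O)NC(=O)N1C)c1ccc(-c2ccc3cccc(F)c3c2)[nH]c1=O` gives 11100 nM. Compound 1 lies within the usual scatter of both of the others, so these numbers give it no real rank.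

Compound 4 `CC(C)C(CC1NC(=O)NC1=O)c1ccc(-c2ccc3cccc(F)c3c2)[nH]c1=O` has not yet been measured in this assay. It differs from compound 1 in one place: a group of 8 heavy atoms (4 carbon, 2 nitrogen, 2 oxygen; one five-membered non-aromatic ring with 2 hetero atoms) in place of a group of 8 heavy atoms (4 carbon, 2 nitrogen, 2 oxygen; one five-membered non-aromatic ring with 2 hetero atoms), on a saturated chain carbon bound to an aromatic carbon and a saturated chain carbon. The entering (2,5-dioxoimidazolidin-4-yl)methyl group has 2 double bonds outside aromatic rings, where the leaving group has 3.

Within the data shown here, no measured pair isolates this change, so the expectation rests on the narrow spread of the series. Compound 2 at 6900 nM and compound 3 at 11100 nM both stay within the scatter of compound 1, so no step beyond the scatter is expected. The expected step is a 1.0-fold higher number from compound 1 to compound 4 (0.02 log units; within the scatter), with no firm direction. For compound 4 the estimated value is 7800 nM, with an expected range from 3800 nM to 16000 nM.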

Compound 4, solubility: 13000 nM
For compound 4 the middle estimate is 1.7-fold (0.22 log units) below the measured one; the measured number falls inside the stated range.
By their numbers in this assay, from the lowest: compounds 2, 1, 3 and 4 (each within the scatter of the next).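

In this assay, among these compounds, placing (2,5-dioxoimidazolidin-4-yl)methyl on a saturated chain carbon bound to an aromatic carbon and a saturated chain carbon gives the first single-place step (a 1.7-fold higher number from compound 1 to compound 4 (0.24 log units; within the scatter)). The entering group has 2 double bonds outside aromatic rings where the leaving group has 3, while its heavy atoms, hydrogen-bond donors and hydrogen-bond acceptors match in count, and this exchange stays within the scatter. No measured property is available to explain this result.

From the compounds shown here alone, whether a different kind of group at this place, such as a carboxylic acid or an amine, would give a step beyond the scatter stays open. Also open, going by these compounds, is whether a longer chain carrying the same five-membered ring would stay within the scatter of compound 4.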